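The source may hold more compounds than are shown below. What is called first, only, known or untested is meant among the compounds shown, and "the series" means these compounds.

Compound 1 `C[Se]c1nc(N)c2ccccc2n1`: 74800 nM
Compound 2 `CCCCC[Se]c1nc(NCc2ccccc2)c2ccccc2n1`: > 100000 nM
Compound 3 `Nc1nc([SeH])nc2ccccc12`: > 100000 nM

In a functional assay on HT-29 cells (Homo sapiens) for cytotoxicity, read by MTT assay, with a stated time of 72 h (on this read-out lower numbers stand for stronger inhibition of growth and higher numbers for weaker inhibition of growth), only compound 1 gives a plain number, 74800 nM. For compound 3 the read-out is a limit of the assay, > 100000 nM. For compound 2 the read-out is likewise a limit, > 100000 nM. Compound 3 therefore stands at the edge of what this assay resolves, as one of two such values among the three (the limit of > 100000 nM in this assay, at which 2 of the 3 values shown sit). Within the data shown here, the only measured step that reaches compound 3, an at least 1.3-fold higher number from compound 1 to compound 3 (0.12 log units; that floor lies within the scatter), runs from a number to a limit, and its floor lies within the scatter.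

Compound 4 `CCCCC[Se]c1nc(N)c2ccccc2n1` differs from compound 3 by pentyl in place of hydrogen on a selenium. Among the measured compounds shown here, the single measured step that bears on this change, an at least 1.3-fold higher number from compound 1 to compound 3 (0.12 log units; that floor lies within the scatter), also concerns an alkyl on the same selenium, in the opposite direction, and is small. For the measured compounds named here, compound 2 also carries pentyl on the selenium, together with a benzyl on the nitrogen, and no step to it is counted. Going by the values given here, nothing among the measured steps points to a move beyond the scatter in this assay. Compound 4 is accordingly expected to remain near the limit, at 95000 nM, with a range from 40000 nM to 220000 nM. The expected step of an at least 1.0-fold lower number from compound 3 to compound 4 (0.02 log units; that floor lies within the scatter) is within the scatter, with a real chance that only a limit is reported.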

Compound 4, concentration for total growth inhibition: > 100000 nM
Compound 4: only a limit was reported; the forecaster's own chance of this, stated with the estimate: 55%; middle value at least 1.0-fold (0.02 log units) away from the limit.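

In this assay compound 4 gives > 100000 nM, which is a limit of the assay. The one step that can be read is an at least 1.3-fold higher number from compound 1 to compound 4 (0.12 log units; that floor lies within the scatter), so a pentyl chain on the selenium in place of methyl is not shown to move the read-out in either direction, and the limit seen for compound 2 now also appears without the benzyl on the nitrogen. The steps joining compound 4 to compound 2 and to compound 3 cannot be read, as all three compounds sit at the same ceiling, and hydrogen, pentyl and the added benzyl cannot be told apart there: the limit of > 100000 nM in this assay, at which 3 of the 4 values shown sit.

Among these compounds, compound 1 remains the only plain number in this assay, at 74800 nM, so the series has no measured value to set any trend against, and what the selenium substituent contributes to growth inhibition stays open. Whether a carboxylic acid or an amine at the end of the selenium chain, a chain longer than pentyl, or a different group on the nitrogen of the shared core would bring a compound clear of this limit is not answered by the compounds shown.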